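The source may report more compounds than this note shows. Statements on the series, on what has been measured and on what is new or still open speak of the compounds shown alone.

Measured in a functional assay on PLC-PRF-5 cells (Homo sapiens) for inhibition, read by MTT assay, with a stated time of 72 h; a lower number here means a stronger inhibitor, a higher number a weaker inhibitor:
- compound 1 `CNC(=O)CCCCCCCn1nc(-c2cnc3[nH]ccc3c2)c2c(N)ncnc21`: 35900 nM
- compound 2 `Nc1ncnc2c1c(-c1cnc3[nH]ccc3c1)nn2CCCCCC(=O)NO`: > 150000 nM (a limit of the assay, not a number)
- compound 3 `Nc1ncnc2c1c(-c1cnc3[nH]ccc3c1)nn2CCCCCCCCCC(=O)NO`: 34200 nM

Compound 3 stands level with compound 1, as a 1.0-fold lower number from compound 1 to compound 3 (0.02 log units; within the scatter) lies within the scatter. It sits clearly on the stronger side of compound 2, with an at least 4.3-fold lower number from compound 2 to compound 3 (0.64 log units; beyond the scatter).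

The unmeasured compound 4 `Nc1ncnc2c1c(-c1cnc3[nH]ccc3c1)nn2CCCCCCC(=O)NO` differs from compound 3 by hydroxycarbamoyl in place of 3-(hydroxycarbamoyl)propyl on a saturated chain carbon, six bonds along the chain from an aromatic nitrogen. Hydroxycarbamoyl takes the place of 3-(hydroxycarbamoyl)propyl, six bonds along the chain from an aromatic nitrogen.

The step that bears most directly is an at least 4.3-fold lower number from compound 2 to compound 3 (0.64 log units; beyond the scatter), where 4-(hydroxycarbamoyl)butyl enters in place of hydroxycarbamoyl. Going from compound 3 to compound 4 runs the same kind of change in reverse, but removes a smaller piece of the chain. Only part of that step is therefore expected to be undone. Its size is also only a bound, as the limit of > 150000 nM in this assay, at which 1 of the 3 values shown sits, shows. The step of a 1.0-fold lower number from compound 1 to compound 3 (0.02 log units; within the scatter) changes the chain end as well as its length, so it adds little here.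

In this assay, a modest move towards a higher number is expected, estimated as a 2.5-fold higher number from compound 3 to compound 4 (0.40 log units; beyond the scatter). For compound 4 the estimated value is 85000 nM, with an expected range of 40000 nM to 200000 nM.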

Compound 4, half-maximal inhibitory concentration: > 50000 nM
Compound 4 was reported as a limit; the forecaster's own chance of this, stated with the estimate: 35%; the middle value does not contradict the limit.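

Compound 4 enters the series only as a limit in this assay, not as a number: the limit of > 50000 nM in this assay, at which 1 of the 4 values shown sits.

With hydroxycarbamoyl in place of 3-(hydroxycarbamoyl)propyl, six bonds along the chain from an aromatic nitrogen, the result gives an at least 1.4-fold higher number from compound 3 to compound 4 (0.16 log units; that floor lies within the scatter), so this shortening is not shown to raise the number beyond the scatter, although the true gap could be larger. The comparison with the methylcarbamoyl compound is equally bounded, at an at least 1.3-fold higher number from compound 1 to compound 4 (0.14 log units; that floor lies within the scatter), while the steps linking compound 2 and compound 4 cannot be read, as both are reported as limits.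

The compounds shown therefore leave open where compound 4 actually lies, and thus whether the shorter hydroxycarbamoyl chains of compound 2 and compound 4 differ from each other at all in this assay. They also leave open whether a longer chain than that of compound 3, or a carboxylic acid in place of the hydroxycarbamoyl end, would move the number in this assay.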